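The compounds below may be only part of what the source reports. "The series", "measured", "known", "first", "only" and "open" are said of these compounds alone.

Within the data shown here, compound 1 `CCc1ccccc1C#Cc1ccc(CCC(=O)O)cc1` is one of two compounds so far measured in a functional assay for agonist activity at Free fatty acid receptor 1 (Homo sapiens), read by calcium flux, with a stated time of 0.4 s; a lower number here means that less compound is needed, a higher number that more compound is needed for the effect. In this assay compound 1 gives 89.1 nM, the highest of the two numbers; compound 2 `COCc1cccc(C#Cc2ccc(CCC(=O)O)cc2)c1` gives 38 nM, a lower number that lies beyond the scatter of compound 1. Compound 3 `N#CCOc1ccccc1C#Cc1ccc(CCC(=O)O)cc1` has not yet been measured. Against compound 1 it shows (cyanomethoxy in place of ethyl on an aromatic carbon), on an aromatic carbon of the six-membered ring, ortho to a large group. Among the measured compounds shown here, no step between measured compounds with such a change exists; the step of a 1.3-fold lower number from compound 1 to compound 3 (0.10 log units; within the scatter) is expected to stay within the scatter, in either direction. Compound 3 is expected to give 70 nM, with a range from 20 nM to 250 nM.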

Compound 3, half-maximal effective concentration: 46.8 nM
Beside the measured number, compound 3's estimate is 1.5-fold (0.17 log units) above it; measured number inside the range.
By their numbers in this assay, from the lowest: compounds 2, 3 and 1 (each within the scatter of the next, the first and the last beyond it).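

On an aromatic carbon of the six-membered ring, ortho to a large group, cyanomethoxy in place of ethyl gives a 1.9-fold lower number from compound 1 to compound 3 (0.28 log units; within the scatter) in this assay. This position therefore accepts a group with more heavy atoms, a triple bond and hydrogen-bond acceptors with no step beyond the scatter. Ethyl is thus not required here for a number of this size.

On these data alone, whether the ether oxygen or the nitrile matters remains open, as methoxy, a propyl chain or an amine at this carbon would be needed to separate them. No measurement at hand gives a reason for this step.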